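The source may hold more compounds than are shown below. What is called first, only, known or untested is meant among the compounds shown, and "the series" means these compounds.

Measured so far:
- compound 1, `CCCCn1ccc2cc(/C(C)=C/C(=O)Nc3ccccc3OCCCC(=O)O)ccc21`: 43 nM
- compound 2, `CCC(C)n1ccc2cc(/C(C)=C/C(=O)Nc3ccccc3OCCCC(=O)O)ccc21`: 67 nM
- compound 3, `CCCC(C(C)C)n1ccc2cc(/C(C)=C/C(=O)Nc3ccccc3OCCCC(=O)O)ccc21`: 7.2 nM

In an assay on Prostate gland for inhibition of steroid 5-alpha-reductase (Rattus norvegicus) (a higher number here means a weaker inhibitor, a lower number a stronger inhibitor), compound 1 stands second highest of the three numbers, with compound 2 within the scatter of it and compound 3 well below it. Compound 4, `C/C(=C\C(=O)Nc1ccccc1OCCCC(=O)O)c1ccc2c(ccn2C(C)c2ccccc2)c1`, differs from compound 1 by one change: 1-phenylethyl in place of butyl on an aromatic nitrogen. Among the compounds with values here, two measured steps concern the same aromatic nitrogen. The step of a 1.6-fold higher number from compound 1 to compound 2 (0.19 log units; within the scatter) changed nothing beyond the scatter, whereas a 6.0-fold lower number from compound 1 to compound 3 (0.78 log units; beyond the scatter) and a 9.3-fold lower number from compound 2 to compound 3 (0.97 log units; beyond the scatter) show that a larger group branched at the carbon bound to that nitrogen went with a modestly lower number. The 1-phenylethyl group is branched at that carbon and larger than sec-butyl, so a modest step toward a lower number, a 2.2-fold lower number from compound 1 to compound 4 (0.33 log units; beyond the scatter), is expected. Compound 4 is estimated at 20 nM, expected between 7 nM and 60 nM.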

Compound 4, half-maximal inhibitory concentration: 19 nM
For compound 4 the middle estimate is 1.1-fold (0.02 log units) above the measured one; the measured number falls inside the stated range.
By their numbers in this assay, from the lowest: compound 3; then compound 4; then compounds 1 and 2 (each within the scatter of the next).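

In this assay the aromatic nitrogen tolerates a group carrying a six-membered aromatic ring, with a 2.3-fold lower number from compound 1 to compound 4 (0.35 log units; beyond the scatter) on replacing butyl and a 3.5-fold lower number from compound 2 to compound 4 (0.55 log units; beyond the scatter) on replacing ethyl with phenyl. The ring is not needed for the lowest number here, as 1-isopropylbutyl gives way to 1-phenylethyl with a 2.6-fold higher number from compound 3 to compound 4 (0.42 log units; beyond the scatter) in this comparison. No measurement shown explains these differences. Still open, going by these compounds, is how an amine or a carboxylic acid on that carbon, or an unbranched benzyl group on the nitrogen, would compare.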